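Caco-2 permeability notes: tert-butyl to trifluoromethyl

A few compounds are considered here, and "the series" means these few. Any claim that something is new, unique, unknown or untested is made for them only; others in the source may bear on it.

Measured so far:
Compound 1, `CNC(=O)c1cc(Oc2ccc3nc(Nc4cccc(C(C)(C)C)c4)ncc3c2)ccn1`, in an ADME assay on Caco-2 cells (Homo sapiens) for permeability, in the apical to basolateral direction (on this read-out higher numbers stand for higher permeability and lower numbers for lower permeability), gives < 1 10^-6 cm/s, which is a limit of the assay and not a number.
Compound 2, `CNC(=O)c1cc(Oc2ccc3nc(Nc4cccc(C(C)(C)C)c4)ccc3c2)ccn1`, in this assay gives < 1 10^-6 cm/s, again a limit.
Compound 3, `CNC(=O)c1cc(Oc2ccc3nc(Nc4cccc(Cl)c4)ncc3c2)ccn1`, in this assay gives < 1 10^-6 cm/s, again a limit.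

Going by the values given here, compound 1 therefore stands only at a limit in this assay; every value shown so far sits at the limit of < 1 10^-6 cm/s in this assay, at which 3 of the 3 values shown sit, so no compound in the set has yet given a readable number.

Compound 4, `CNC(=O)c1cc(Oc2ccc3nc(Nc4cccc(C(F)(F)F)c4)ncc3c2)ccn1`, differs from compound 1 by trifluoromethyl in place of tert-butyl on an aromatic carbon. Among the compounds with values here, the only measured step at the same place is a step that the two limits leave unreadable from compound 1 to compound 3, which exchanges tert-butyl for chloro, and both of its ends are limits, so its size cannot be read. Nothing in the measured set shows a change at this place moving the read-out out of the limit.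

On that basis compound 4 is expected to give 0.7 10^-6 cm/s in this assay, with a range from 0.2 10^-6 cm/s to 2.5 10^-6 cm/s. The expected step that the limit leaves unreadable from compound 1 to compound 4 is thus none that can be read beyond the limit, and a further limit rather than a number is the more likely report.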

Compound 4, apparent permeability: < 1 10^-6 cm/s
Compound 4: no number, only a limit (the forecaster's own chance of this, stated with the estimate: 70%); the middle value lies beyond the limit too.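

Compound 4 is a limit, not a number, in this assay, so the steps to it from compound 1 and compound 3 cannot be read: the limit of < 1 10^-6 cm/s in this assay, at which 4 of the 4 values shown sit.

The compounds shown leave open whether tert-butyl, chloro and trifluoromethyl differ at all on this read-out.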